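Replacing the Benzyl Amide with a Free Acid

This account rests on a few compounds, and the source may have more. Where it says the series, first, only, none or still open, it means among the compounds named here.

Compound 2 `C=CC1=C(C(=O)NCc2ccccc2)C(c2ccc(Cl)c(Cl)c2)OC1` is a close relative of compound 1 `C=CC1=C(C(=O)NC(C)(C)C)C(c2ccc(Cl)c(Cl)c2)OC1`; the two share a core and differ only in the group on the amide-type nitrogen. In a functional assay on A549 cells (Homo sapiens) for cytotoxicity, read by MTT assay, with a stated time of 24 h (on this read-out higher numbers stand for weaker inhibition and lower numbers for stronger inhibition), compound 1 gives > 100000 nM, which is a limit of the assay rather than a number. In this assay compound 2 gives > 100000 nM, again a limit of the assay. The step that the two limits leave unreadable from compound 1 to compound 2 therefore cannot be read. Both values sit at the same point, as the limit of > 100000 nM in this assay, at which 2 of the 2 values shown sit, shows. Compound 2 thus stands at the edge of what the assay can report, with no measured number of its own.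

Compound 3 `C=CC1=C(C(=O)O)C(c2ccc(Cl)c(Cl)c2)OC1` is the next change: hydroxy in place of benzylamino on a carbonyl carbon. Going by the values given here, no measured step bears on this change: the one step measured is unreadable and concerns the other end of the amide. With nothing to point to beyond the two limits, the expectation is that compound 3 also reaches no measurable inhibition in this assay, and the expected step that the limit leaves unreadable from compound 2 to compound 3 is none beyond the scatter. Compound 3 is estimated at 150000 nM, with a range from 30000 nM to 500000 nM.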

Compound 3, half-maximal inhibitory concentration: > 100000 nM
Compound 3 ended at the assay's limit; the forecaster's own chance of this, stated with the estimate: 85%; the middle value does not contradict the limit.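

In this assay compound 3 gives > 100000 nM, which is a limit of the assay and not a number. The steps linking compound 1, compound 2 and compound 3 therefore cannot be read, with all three at one point: the limit of > 100000 nM in this assay, at which 3 of the 3 values shown sit.

The compounds shown leave open whether any change on the carbonyl carbon can bring a measurable value in this assay.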